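The compounds below may be only part of what the source reports. "The series", "measured", "known", "first", "only" and "open" are said of these compounds alone.

Compound 1 `CC(C)Sc1nc(Cc2c(F)cccc2F)cc(=O)[nH]1` was tested in a functional assay on MT4 cells (Homo sapiens) for cytotoxicity (on this read-out higher numbers stand for lower toxicity in this test and lower numbers for higher toxicity in this test), and compound 1 reaches only the limit of > 200000 nM, so no number is known for it. Two close relatives stand at the same limit. Compound 2 `CCC(C)Sc1nc(O)cc(Cc2c(F)cccc2F)n1` reaches the limit of > 200000 nM. Compound 3 `O=c1cc(Cc2c(F)cccc2F)nc(SC2CCCC2)[nH]1` likewise reaches the limit of > 200000 nM. The step that the two limits leave unreadable from compound 1 to compound 3 therefore cannot be read. Going by the values given here, every value so far sits at the limit of > 200000 nM in this assay, at which 3 of the 3 values shown sit.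

Compound 4 `Cc1c(Cc2c(F)cccc2F)nc(SC(C)C)[nH]c1=O` differs from compound 1 by methyl in place of hydrogen on an aromatic carbon. Among the compounds with values here, no measured pair touches this position of the shared core, so no step speaks directly to the change, and the one comparison at hand, from compound 1 to compound 3, is unreadable from the two limits. With every value at a limit, the expectation is that compound 4 also reaches the limit, so the expected step of a number no higher from compound 1 to compound 4 (the limit leaves the size open) is none beyond the scatter. Compound 4 is estimated at 200000 nM, within a range from 100000 nM to 400000 nM.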

Compound 4, half-maximal cytotoxic concentration: > 200000 nM
Compound 4 gave a limit, no number (the forecaster's own chance of this, stated with the estimate: 85%); the middle value sits exactly at the limit.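

Compound 1 and compound 4 both stand at a limit rather than a number, so the change between them cannot be read: the limit of > 200000 nM in this assay, at which 4 of the 4 values shown sit. The compounds shown leave open whether any change to the shared core would give an actual number in this assay.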